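The compounds below may be only part of what the source reports. "The series", "measured", "known", "first", "only" and "open" are said of these compounds alone.

The study reads growth inhibition in a functional assay on HTB-54 cells (Homo sapiens) for cytotoxicity, read by MTT assay, with a stated time of 72 h; on this read-out lower numbers stand for stronger inhibition of growth and higher numbers for weaker inhibition of growth. Compound 1 `COc1ccc(CNc2nc(SC)nc3ncccc23)cc1` is one of three compounds with a result there. In this assay compound 1 gives > 100000 nM, which is a limit of the assay and not a number. Compound 1 therefore stands at the edge of what the assay reports, at the limit of > 100000 nM in this assay, at which 1 of the 3 values shown sits. For the measured compounds named here, compound 2 `Nc1nc([SeH])nc2ncccc12` gives 44300 nM in this assay, and compound 3 `[SeH]c1nc(NCc2ccccc2)c2ccccc2n1` gives 31200 nM in this assay; no step between any pair of these three is available, as each differs from the others in more than one place.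

Compound 4 `CSc1nc(NCc2ccccc2)c2cccnc2n1` has not yet been measured. It differs from compound 1 by hydrogen in place of methoxy on an aromatic carbon. Going by the values given here, no measured step covers this change, so the expectation rests on compound 1 alone, which gives only a limit. A step of no more than the usual scatter, in either direction, is expected, and compound 4 is expected to remain near that limit. Its concentration for half-maximal growth inhibition in this assay is estimated at 120000 nM, with a range from 30000 nM to 500000 nM. The expected step is a step that the limit leaves unreadable from compound 1 to compound 4.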

Compound 4, concentration for 50% growth inhibition: 5080 nM
For compound 4 the middle estimate is 24-fold (1.37 log units) above the measured one; the measured number lies below the stated range.
By their numbers in this assay, from the lowest: compound 4; then compounds 3 and 2 (each within the scatter of the next). At a limit, above all of these: compound 1.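

In this assay, hydrogen in place of methoxy on an aromatic carbon, para to a large group, gives an at least 19-fold lower number from compound 1 to compound 4 (1.29 log units; beyond the scatter). For the compounds shown here, this is the first single change that can be read, and it shows that growth inhibition at this position depends on what the ring carbon carries, which compounds 1, 2 and 3 could not show, as no two of them differ in one place only. Compound 1 gives a limit of the assay and not a number, so the step has no exact size: the limit of > 100000 nM in this assay, at which 1 of the 4 values shown sits.

The compounds shown leave open how other groups at this position, such as fluorine, chlorine, methyl or hydroxyl, would compare with hydrogen and methoxy. They also leave open whether an amine or a longer chain elsewhere on compound 4 would move its number.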